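The compounds below may be only part of what the source reports. "The series", "measured", "known", "first", "only" and "open" are said of these compounds alone.

Working notes on the series. Compound 1 `CC(C)OC(=O)N1CCC(COc2ccc(N3CCN(S(=O)(=O)C(C)C)CC3)nc2)CC1` and compound 2 `CCCS(=O)(=O)N1CCN(c2ccc(OCC3CCN(C(=O)NC(C)C)CC3)cn2)CC1` share the same core and differ in more than one place. In a functional assay on CHO-K1 cells for agonist activity at Glucose-dependent insulinotropic receptor (Homo sapiens), read by a luciferase reporter, with a stated time of 5 h (a lower number here means that less compound is needed, a higher number that more compound is needed for the effect), compound 1 gives 300 nM, and compound 2 gives 1000 nM, the higher of the two numbers, with the gap to compound 1 beyond the scatter. Compound 3 `CCCS(=O)(=O)N1CCN(c2ccc(OCC3CCN(C(=O)C(F)F)CC3)cn2)CC1` is not yet measured; it differs from compound 2 by difluoromethyl in place of isopropylamino on a carbonyl carbon. Among the compounds with values here, no single-change step is known here, so the step is expected to be small, if any, with no clear direction, as a 1.7-fold lower number from compound 2 to compound 3 (0.22 log units; within the scatter). Compound 3 is expected to give about 600 nM in this assay, within 200 nM to 2000 nM.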

Compound 3, half-maximal effective concentration: 2100 nM
For compound 3 the middle estimate is 3.5-fold (0.54 log units) below the measured one; the whole stated range lies below it.
By their numbers in this assay, from the lowest: compound 1; then compound 2; then compound 3.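

On the carbonyl carbon whose other neighbour is the amide-type nitrogen in a ring, difluoromethyl in place of isopropylamino gives a 2.1-fold higher number from compound 2 to compound 3 (0.32 log units; beyond the scatter) in this assay, a modest step. Agonist activity therefore survives at this position without the isopropylamino group and its hydrogen-bond donor, though more compound is needed. Whether the amide hydrogen or the isopropyl part accounts for the step stays open. A methylamino or tert-butyl group on the same carbonyl carbon would help separate the two. Nothing measured here explains the step.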